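Swapping the aryl group on the shared core: compound 3

A few compounds are considered here, and "the series" means these few. Any claim that something is new, unique, unknown or untested is made for them only; others in the source may bear on it.

Working notes on the series. Two compounds carry measurements in a functional assay on the whole organism (liver, strain NMRI) for inhibition, with Mus musculus as the target, with a stated time of 3 h, at a dose of 3 mg/kg by the oral route; a lower number here means less inhibition, a higher number more inhibition at the dose given (going by the name of the read-out). Compound 1 `O=[N+]([O-])c1cc(-c2nc(-c3ccc(F)cc3)no2)cc(O)c1O` gives 12.7% in this assay, while compound 2 `CC(=O)N1CCN(c2noc(-c3cc(O)c(O)c([N+](=O)[O-])c3)n2)CC1` gives 68.2%. Of these two numbers compound 1 is the lower one, and compound 2 stands well above it, with a gap beyond the usual scatter. Among the compounds with values here, compound 1 and compound 2 differ in more than one place, so no single step links them; their two values show only that compound 1 holds the lower of the two positions.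

Compound 3 `O=[N+]([O-])c1cc(-c2nc(-c3cccs3)no2)cc(O)c1O` is not yet measured. It differs from compound 1 in one place: thiophen-2-yl in place of 4-fluorophenyl on an aromatic carbon. The remainder of compound 1 is kept unchanged.

Within the data shown here, no measured step of this kind exists, so the expectation rests on compound 1 alone. The expected step is small, either none beyond the scatter or a modest rise in inhibition: a number 5.3 percentage points higher from compound 1 to compound 3 (within the scatter). Compound 3 is therefore estimated to give about 18% in this assay, with an expected range from 3% to 40%.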

Compound 3, a percentage reported as inhibition, in the whole organism at one dose (the size of the read-out at that dose, not a potency): 29.6%
Beside the measured number, compound 3's estimate is 11.6 percentage points below it; the range from low to high includes it.
By their numbers in this assay, from the lowest: compound 1; then compound 3; then compound 2.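

In this assay, thiophen-2-yl in place of 4-fluorophenyl on the aromatic carbon between two ring nitrogen atoms gives a number 16.9 percentage points higher from compound 1 to compound 3 (beyond the scatter). Within the data shown here, this is the first single-place step, and it shows that the read-out at this dose responds to the aryl group at this position, with a five-membered aromatic ring carrying one sulfur atom giving the higher number. The step is modest and rests on one pair, and nothing available bears on why the number rises.

The step changes several things at once: the ring size, the sulfur atom and the loss of fluorine, so the compounds shown leave open which of these goes with the rise; phenyl without fluorine, furan-2-yl or thiophen-3-yl at the same carbon would separate them. Also open, as far as these compounds go, is whether a non-aromatic group at this position, such as a piperidine or another saturated amine, would carry the number further on the unchanged core of compound 1.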